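The compounds below may be only part of what the source reports. "The series", "measured", "known", "first", "only" and "open" are said of these compounds alone.

Compound 3 `CCC(=O)OCc1ccc2oc(=O)c(C(=O)Oc3cccc(Br)c3)cc2c1` gives 21.3% in a functional assay on HT-1080 cells (Homo sapiens), read by transwell migration, with a stated time of 24 h, tested at 10 uM; on this read-out lower numbers stand for a stronger effect and higher numbers for a weaker effect at the one concentration tested. Among the three numbers measured so far it stands lowest: the nearest is compound 2 `CC(=O)OCc1ccc2oc(=O)c(C(=O)Sc3cccc(Cl)c3)cc2c1`, which gives 61.9% in this assay, and the furthest is compound 1 `CC(=O)OCc1ccc2oc(=O)c(C(=O)Sc3ccccc3)cc2c1`, which gives 73.8% in this assay. For the measured compounds named here, the one step between compounds that differ in a single place, a number 11.9 percentage points lower from compound 1 to compound 2 (beyond the scatter), concerns chloro in place of hydrogen on an aromatic carbon and is of modest size.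

Compound 4 `CCCCCCC(=O)OCc1ccc2oc(=O)c(C(=O)Oc3cccc(Br)c3)cc2c1` differs from compound 3 in one place: butyl in place of hydrogen on a saturated chain carbon, two bonds along the chain from a carbonyl carbon. Going by the values given here, no measured step touches the saturated chain on the ester side of the shared core, so the step from compound 1 to compound 2 does not bear on this change directly; it shows only that a single-point change in this set can move this assay by a modest amount. Compound 3 carries a propanoyl group where compound 4 carries hexylcarbonyl, and nothing measured sets a direction for that. The step from compound 3 to compound 4 is therefore expected to stay small, a number 3.7 percentage points higher from compound 3 to compound 4 (within the scatter), with the range kept wide. For compound 4 the estimate in this assay is 25%, expected to fall between 8% and 50%.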

Compound 4, a percentage reported as activity, at one concentration (the size of the read-out at that concentration, not a potency): 36%
Beside the measured number, compound 4's estimate is 11 percentage points below it; low and high end bracket the measured number.
By their numbers in this assay, from the lowest: compound 3; then compound 4; then compound 2; then compound 1.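

In this assay, the change from propanoyl to hexylcarbonyl gives a number 14.7 percentage points higher from compound 3 to compound 4 (beyond the scatter), so this saturated chain position on the ester side does respond to substitution, and butyl in place of hydrogen here weakens the read-out at the one concentration tested. For the compounds shown here, the only earlier step, chloro in place of hydrogen on an aromatic carbon, moved the number down, so this is the first single-place change that moves it up and the first to touch this chain. No measurement offered here accounts for the change at this position.

From the compounds shown here alone, two chain lengths give only a direction between two points, so it stays open whether a butanoyl group would fall on the same line, whether a longer chain such as octanoyl would raise the number further, and whether a branched isobutyryl group or a chain ending in an amine or a carboxylic acid would behave differently. Going by these compounds, it also stays open whether the same chain change would have a similar effect on the thioester compounds, compound 1 and compound 2.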